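The source may hold more compounds than are shown below. What is called first, only, known or untested is meant among the compounds shown, and "the series" means these compounds.

Compound 1 `Cc1ccc(-n2cc(-c3ccccc3NS(=O)(=O)c3c[nH]c(=O)[nH]c3=O)nn2)cc1` is measured in a functional assay on OVCAR-3 cells (Homo sapiens) for antiproliferative activity, read by MTT assay, with a stated time of 24 h (a lower number here means a stronger inhibitor, a higher number a weaker inhibitor), where compound 1 gives 2190 nM. Two companions share its core. Compound 3 `O=c1[nH]cc(S(=O)(=O)Nc2ccccc2-c2cn(-c3cccc(Cl)c3)nn2)c(=O)[nH]1` gives 2180 nM, and the step of a 1.0-fold lower number from compound 1 to compound 3 (0.00 log units; within the scatter) stays within the scatter, so compound 1 and compound 3 cannot be told apart on these numbers. Compound 2 `O=c1[nH]cc(S(=O)(=O)Nc2ccccc2-c2cn(-c3cccc(F)c3)nn2)c(=O)[nH]1` gives > 20000 nM, which is only a limit of the assay rather than a number (the limit of > 20000 nM in this assay, at which 1 of the 3 values shown sits). The step of an at least 9.1-fold higher number from compound 1 to compound 2 (0.96 log units; beyond the scatter) and the step of an at least 9.1-fold lower number from compound 2 to compound 3 (0.96 log units; beyond the scatter) are both beyond the scatter.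

Compound 4 `O=c1[nH]cc(S(=O)(=O)Nc2ccccc2-c2cn(-c3ccc(Cl)cc3)nn2)c(=O)[nH]1` is not yet measured. It differs from compound 1 by chloro in place of methyl on an aromatic carbon. The measured step that bears on this most directly is a 1.0-fold lower number from compound 1 to compound 3 (0.00 log units; within the scatter), which shows that a chloro-bearing ring, at a different position, matches the methyl-bearing ring of compound 1. A chloro group at the same position as the methyl is therefore expected to give a step of about a 1.0-fold higher number from compound 1 to compound 4 (0.00 log units; within the scatter), within the scatter. Compound 4 is thus estimated at 2200 nM, between 900 nM and 5500 nM.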

Compound 4, half-maximal inhibitory concentration: 1750 nM
The estimate for compound 4 lay 1.3-fold (0.10 log units) above the measured number; low and high end bracket the measured number.
By their numbers in this assay, from the lowest: compounds 4, 3 and 1 (each within the scatter of the next). At a limit, above all of these: compound 2.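

Chloro in place of methyl on the aromatic carbon para to a large group gives a 1.3-fold lower number from compound 1 to compound 4 (0.10 log units; within the scatter), and 4-chlorophenyl in place of 3-chlorophenyl gives a 1.2-fold lower number from compound 3 to compound 4 (0.10 log units; within the scatter), so in this assay neither the swap at this position nor the place of the chloro on the ring can be told apart from the scatter. Within the data shown here, compound 2, with its 3-fluorophenyl, remains the one compound that goes against this flat picture, with an at least 11-fold lower number from compound 2 to compound 4 (1.05 log units; beyond the scatter). Compound 2 is held at a limit of the assay, not a number: the limit of > 20000 nM in this assay, at which 1 of the 4 values shown sits.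

On these data alone, what remains open is whether an amine, a methoxy group or a carboxylic acid on the same carbon would keep this level. As far as these compounds go, it is also open whether 4-fluorophenyl would side with compound 2 or with compound 4.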